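Removing the Aminomethyl Arm from a Naphthalene Sulfonamide

A few compounds are considered here, and "the series" means these few. Any claim that something is new, unique, unknown or untested is made for them only; others in the source may bear on it.

Measured compounds and their values in an assay on VSM-A10 cells for antagonist activity at Endothelin-1 receptor (Rattus norvegicus); on this read-out lower numbers stand for stronger inhibition and higher numbers for weaker inhibition:
Compound 1 `CCCCCNc1cccc2c(S(=O)(=O)Nc3onc(C)c3C)cccc12` gives 80 nM.
Compound 2 `Cc1noc(NS(=O)(=O)c2cccc3c(Cl)cccc23)c1C` gives 24000 nM.
Compound 3 `Cc1noc(NS(=O)(=O)c2cccc3c(CN(C)C)cccc23)c1C` gives 2800 nM.

Compound 3 stands second highest of the three numbers in this assay: it is beaten clearly by compound 1, a 35-fold higher number from compound 1 to compound 3 (1.54 log units; beyond the scatter), while compound 2 sits above it, an 8.6-fold lower number from compound 2 to compound 3 (0.93 log units; beyond the scatter). Compound 4 `Cc1noc(NS(=O)(=O)c2cccc3ccccc23)c1C` has not yet been measured. It differs from compound 3 in one place: hydrogen in place of (dimethylamino)methyl on an aromatic carbon.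

Within the data shown here, no measured step removes a group to leave bare hydrogen, so the guide is indirect. The two measured steps on this position show that what sits there matters a great deal: the pentylamino group of compound 1 gives by far the lowest number, the (dimethylamino)methyl group of compound 3 a much higher one, and chloro in compound 2 the highest of all. With nothing at all in that place, a number nearer to compound 2 than to compound 1 seems the more likely outcome, so a rise beyond the scatter is expected, a 4.3-fold higher number from compound 3 to compound 4 (0.63 log units; beyond the scatter). For compound 4 the estimate in this assay is 12000 nM, with a range from 3000 nM to 50000 nM.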

Compound 4, half-maximal inhibitory concentration: 20000 nM
Estimate against measurement, compound 4: 1.7-fold (0.22 log units) below; measured number inside the range.
By their numbers in this assay, from the lowest: compound 1; then compound 3; then compounds 4 and 2 (each within the scatter of the next).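

Among these compounds, compound 4 gives this position the bare-hydrogen baseline that the earlier compounds lacked in this assay, and against it chloro makes no readable difference (a 1.2-fold lower number from compound 2 to compound 4 (0.08 log units; within the scatter)). The (dimethylamino)methyl group does count, since replacing it with hydrogen gives a clear change (a 7.1-fold higher number from compound 3 to compound 4 (0.85 log units; beyond the scatter)), so its lower number compared with chloro also holds against an empty position. The pentylamino group stands much further from that baseline (a 250-fold higher number from compound 1 to compound 4 (2.40 log units; beyond the scatter)), so among these four compounds the two groups containing nitrogen lower the number, while the chloro of compound 2 goes against any idea that every group placed here helps.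

The compounds shown do not separate the part played by the nitrogen from that of the carbon chain, and a plain amine, a butyl chain with no nitrogen or a longer alkylamino chain on the same aromatic carbon would begin to tell these apart. Nothing given here accounts for the size of these differences.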